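Fluorine on the benzamide ring of a uracil-linked amide

This account rests on a few compounds, and the source may have more. Where it says the series, first, only, none or still open, it means among the compounds named here.

Compound 1 `O=C(NC/C=C\Cn1ccc(=O)[nH]c1=O)c1ccccc1` gives > 100000 nM in a functional assay on SK-BR-3 cells (Homo sapiens) for cytotoxicity, read by MTT assay, with a stated time of 72 h (on this read-out lower numbers stand for stronger inhibition and higher numbers for weaker inhibition), which is a limit of the assay and not a number.
Compound 2 `O=C(NC/C=C\Cn1cc(F)c(=O)[nH]c1=O)c1ccccc1` gives > 100000 nM in this assay, again a limit and not a number.

Going by the values given here, compound 1 thus stands at the edge of what this assay reports, and the one companion value shown is also only a limit. The step from compound 1 to compound 2 is a step that the two limits leave unreadable from compound 1 to compound 2. Among the compounds with values here, the only evidence on the measured step is the limit of > 100000 nM in this assay, at which 2 of the 2 values shown sit, so no size can be read from it.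

Compound 3 `O=C(NC/C=C\Cn1ccc(=O)[nH]c1=O)c1ccc(F)cc1` differs from compound 1 in one place: fluoro in place of hydrogen on an aromatic carbon. Within the data shown here, this change sits on the benzamide ring, whereas the one measured step touched the uracil ring, so no measured step bears directly on it. Nothing shown lets one expect a step beyond the scatter in either direction, and compound 3 is expected to stay near the limit. The estimated step from compound 1 to compound 3 is a step that the limit leaves unreadable from compound 1 to compound 3. For compound 3 the expected value is 200000 nM, within 50000 nM to 1000000 nM.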

Compound 3, half-maximal inhibitory concentration: > 100000 nM
Compound 3: no number, only a limit; the forecaster's own chance of this, stated with the estimate: 85%; the middle value lies beyond the limit too.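

In this assay compound 3 gives > 100000 nM, a limit and not a number, so the change from compound 1 to compound 3 yields no readable step, just as the change from compound 1 to compound 2 yielded none: the limit of > 100000 nM in this assay, at which 3 of the 3 values shown sit.

The compounds shown leave open whether fluoro at either place changes the response in this assay at all, and what the true values lie at beyond the limit.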